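The source may report more compounds than this note shows. Statements on the series, on what has been measured and on what is new or still open speak of the compounds shown alone.

Measured so far:
Compound 1, `Cc1c(C(=O)NCc2cccc(N)c2)cnn1-c1ccc(Cl)cc1`. In a functional assay on cells for antagonist activity at C-C chemokine receptor type 1 (Homo sapiens), read by FLIPR and calcium flux (on this read-out higher numbers stand for weaker inhibition and lower numbers for stronger inhibition), compound 1 gives > 3000 nM, which is a limit of the assay and not a number.
Compound 2, `Cc1c(C(=O)NCc2ccccn2)cnn1-c1ccc(Cl)cc1`. In this assay compound 2 gives > 3000 nM, again a limit of the assay rather than a number.

The two measured compounds share one core and differ only in the group carried on the saturated chain carbon bound to the amide-type nitrogen. The step from compound 1 to compound 2, a step that the two limits leave unreadable from compound 1 to compound 2, cannot be read, since both of its ends sit at the limit of > 3000 nM in this assay, at which 2 of the 2 values shown sit. Compound 2 therefore stands at the weak end of what the assay can report, with no number of its own.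

Compound 3, `Cc1c(C(=O)NCc2ccncc2)cnn1-c1ccc(Cl)cc1`, has not yet been measured. It differs from compound 2 by pyridin-4-yl in place of pyridin-2-yl on a saturated chain carbon bound to an amide-type nitrogen. No measured step bears on this change in a readable way; the only step shown is unreadable, so no direction can be drawn from the data. The expected step is a step that the limit leaves unreadable from compound 2 to compound 3, none beyond the scatter. Compound 3 is expected to give about 6000 nM in this assay, in the range 1500 nM to 30000 nM, most likely again as a limit.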

Compound 3, half-maximal inhibitory concentration: > 3000 nM
Compound 3 gave a limit, no number (the forecaster's own chance of this, stated with the estimate: 80%); the middle value does not contradict the limit.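

In this assay compound 3 gives > 3000 nM, which is a limit of the assay and not a number. No step among compound 1, compound 2 and compound 3 can be read, because all three sit at the same limit: the limit of > 3000 nM in this assay, at which 3 of the 3 values shown sit.

The compounds shown leave open how pyridin-2-yl, pyridin-4-yl and 3-aminophenyl actually compare, and whether any group at this place gives a measurable value.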